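The compounds below may be only part of what the source reports. "The series", "measured", "known", "first", "only" and "open" are said of these compounds alone.

Values so far in a functional assay on HL-60 cells (Homo sapiens), read by calcium flux (on this read-out lower numbers stand for an effect already at smaller amounts and higher numbers for an effect only at larger amounts of compound), all three of them limits:

compound 1 `COc1cc(Cc2cc(C)nn(CC(=O)Nc3ccc(Br)cc3)c2=O)cc(OC)c1`: > 50000 nM
compound 2 `Cc1cc(Cc2ccoc2)c(=O)n(CC(=O)Nc2ccc(Br)cc2)n1`: > 50000 nM
compound 3 `Cc1cc(Cc2cccc3ccccc23)c(=O)n(CC(=O)Nc2ccc(Br)cc2)n1`: > 50000 nM

Compound 2 has no number, only the limit > 50000 nM. The whole set shares this position: the limit of > 50000 nM in this assay, at which 3 of the 3 values shown sit.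

The next compound is compound 4 `COc1ccc(-c2cc(C)nn(CC(=O)Nc3ccc(Br)cc3)c2=O)cc1`. The change from compound 2 is 4-methoxyphenyl in place of (furan-3-yl)methyl on an aromatic carbon. In words, 4-methoxyphenyl stands in place of (furan-3-yl)methyl on an aromatic carbon, opposite the ring nitrogen.

Among the compounds with values here, three measured steps bear on this, and only loosely: a step that the two limits leave unreadable from compound 1 to compound 2, a step that the two limits leave unreadable from compound 1 to compound 3 and a step that the two limits leave unreadable from compound 2 to compound 3. None of them has a readable size. Within the data shown here, all three exchange the group on a saturated chain carbon, whereas compound 4 carries its 4-methoxyphenyl on an aromatic carbon, so no measured step covers this kind of change.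

With no size to carry over, the expectation in this assay rests on the three limits alone, and another limit is the likeliest result. If a number does appear, it should lie toward the weak end of the scale. The expected step, held with low confidence, is an at least 1.6-fold lower number from compound 2 to compound 4 (0.22 log units; that floor lies within the scatter). Compound 4 is estimated at 30000 nM, with an expected range from 5000 nM to 50000 nM.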

Compound 4, half-maximal effective concentration: > 50000 nM
Compound 4 gave a limit, no number; the forecaster's own chance of this, stated with the estimate: 70%; middle value at least 1.6-fold (0.22 log units) away from the limit.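

In this assay compound 4 gives > 50000 nM as a limit and not a number. Within the data shown here, compound 2 also has only a limit, so no step from compound 2 to compound 4 can be read. The compounds shown leave open whether any change on the shared core gives a number in this assay at all, as the whole set sits at one position: the limit of > 50000 nM in this assay, at which 4 of the 4 values shown sit.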